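This account rests on a few compounds, and the source may have more. Where it says the series, first, only, none or still open, it means among the compounds named here.

Working notes on an ADME assay on microsomes from liver (Homo sapiens) for metabolic stability; a lower number here means slower removal, a higher number faster removal of the compound. Compound 1 `Cc1cc2ncncc2cc1Nc1ncc2c(n1)n(C1CCOCC1)c(=O)n2C` reads > 200 mL.min-1.g-1, a limit of the assay. Compound 3 `Cc1cc2nnccc2cc1Nc1ncc2c(n1)n(C1CCN(C)CC1)c(=O)n2C` gives a measured number, 17 mL.min-1.g-1. Compound 2 `Cc1cc2ncccc2cc1Nc1ncc2c(n1)n(C1CCN(C)CC1)c(=O)n2C` reads < 4 mL.min-1.g-1, also a limit, and so stands at the low end of the three results, with no exact number available. The next structure is compound 4 `Cc1cc2ncccc2cc1Nc1ncc2c(n1)n([C@H]1CCN(C3COC3)C1)c(=O)n2C`, which carries 1-(oxetan-3-yl)pyrrolidin-3-yl in place of 1-methylpiperidin-4-yl on an aromatic nitrogen. For the measured compounds named here, no measured pair isolates this change, so only a modest upward move in this assay is expected, an estimated at least 2.0-fold higher number from compound 2 to compound 4 (0.30 log units; that floor lies within the scatter). For compound 4 the estimated value is 8 mL.min-1.g-1, with an expected range of 3 mL.min-1.g-1 to 25 mL.min-1.g-1.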

Compound 4, intrinsic clearance in microsomes: 33 mL.min-1.g-1
The estimate for compound 4 lay 4.1-fold (0.62 log units) below the measured number; the measured number lies above the stated range.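

In this assay, 1-(oxetan-3-yl)pyrrolidin-3-yl in place of 1-methylpiperidin-4-yl on the aromatic nitrogen gives an at least 8.2-fold higher number from compound 2 to compound 4 (0.91 log units; beyond the scatter). For the compounds shown here, this is the first measured pair that isolates a change at this position, and the shift lies beyond the scatter. Only a floor can be given for the step because compound 2 is a limit of the assay: the limit of < 4 mL.min-1.g-1 in this assay, at which 1 of the 4 values shown sits.

From the compounds shown here alone, whether the step belongs to the five-membered ring or to the oxetane remains open. Comparing 1-methylpyrrolidin-3-yl or 1-(oxetan-3-yl)piperidin-4-yl at this position would separate the two.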